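Methyl for fluoro on the phenyl of the shared core

This account rests on a few compounds, and the source may have more. Where it says the series, first, only, none or still open, it means among the compounds named here.

Compound 1 is `O=c1sn(-c2ccccc2)c(=O)n1-c1ccccc1`. In an ADME assay, in phosphate buffer, with a stated time of 30 min, tested at 1 mM, at a dose of 1 mM (a lower number here means less compound in the circulation, a higher number more compound in the circulation at the dose given), compound 1 gives < 2000 nM, which is a limit of the assay and not a number. Compound 2 is `O=c1sn(-c2ccc(F)cc2)c(=O)n1-c1ccccc1`, the fluoro analogue. In this assay compound 2 gives < 2000 nM, again a limit and not a number. The step from compound 1 to compound 2 is a step that the two limits leave unreadable from compound 1 to compound 2, so its size cannot be read. Both values sit at the limit of < 2000 nM in this assay, at which 2 of the 2 values shown sit.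

Among the compounds with values here, compound 2 stands therefore only at a limit in this assay, and the one further value shown is a limit too.

Compound 3 is `Cc1ccc(-n2sc(=O)n(-c3ccccc3)c2=O)cc1`. It differs from compound 2 as methyl in place of fluoro on an aromatic carbon. Within the data shown here, the only measured step, from compound 1 to compound 2, bears on the same aromatic carbon, but its size is unreadable, so it gives no direction for the methyl change. No step beyond the scatter is expected, and the value is expected to remain near the limit.

For compound 3 in this assay the estimate is 1200 nM, between 300 nM and 3000 nM. The estimated step from compound 2 to compound 3 is a step that the limit leaves unreadable from compound 2 to compound 3.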

Compound 3, maximal plasma concentration: < 2000 nM
Compound 3: only a limit was reported (the forecaster's own chance of this, stated with the estimate: 70%); the middle value lies beyond the limit too.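

In this assay no new step can be read among compound 1, compound 2 and compound 3, since each gives only a limit of the assay and not a number: the limit of < 2000 nM in this assay, at which 3 of the 3 values shown sit. On these data alone, whether hydrogen, fluoro or methyl on this aromatic carbon makes any difference to the maximal plasma concentration, and how large it would be, stays open.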